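Swapping Nitro for Methoxy: What to Expect for Compound 3

The source may report more compounds than this note shows. Statements on the series, on what has been measured and on what is new or still open speak of the compounds shown alone.

Compound 1 `O=[N+]([O-])c1ccccc1CSc1nnc(-c2ccc3c(c2)OCCO3)n1-c1ccccc1` and compound 2 `O=[N+]([O-])c1cccc(CSc2nnc(-c3ccc4c(c3)OCCO4)n2-c2ccccc2)c1` share one core and differ only in the position of the nitro. Among the compounds with values here, in a functional assay on HepG2 cells (Homo sapiens) for antiproliferative activity, read by MTT assay, with a stated time of 24 h (a higher number here means a weaker inhibitor, a lower number a stronger inhibitor), compound 1 gives 12000 nM, while compound 2 gives 49300 nM, the higher of the two numbers; the only measured step, a 4.1-fold higher number from compound 1 to compound 2 (0.61 log units; beyond the scatter), concerns where the nitro sits, not its identity. Compound 3 `COc1cccc(CSc2nnc(-c3ccc4c(c3)OCCO4)n2-c2ccccc2)c1` carries methoxy in place of nitro on an aromatic carbon. Within the data shown here, no measured step speaks to this exchange, so no step beyond the scatter is expected in either direction. Compound 3 is therefore estimated at 49000 nM, with a range from 15000 nM to 160000 nM. That estimate corresponds to the expected step of a 1.0-fold lower number from compound 2 to compound 3 (0.00 log units; within the scatter).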

Compound 3, half-maximal inhibitory concentration: 35100 nM
Estimate against measurement, compound 3: 1.4-fold (0.14 log units) above; the measured number falls inside the stated range.
By their numbers in this assay, from the lowest: compound 1; then compounds 3 and 2 (each within the scatter of the next).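

In this assay the exchange of 3-nitrophenyl for 3-methoxyphenyl gives a 1.4-fold lower number from compound 2 to compound 3 (0.15 log units; within the scatter) and stays within the scatter, so at this place the two groups cannot be told apart. The step of a 2.9-fold higher number from compound 1 to compound 3 (0.47 log units; beyond the scatter) changes both the group and its place, and it leaves the 2-nitrophenyl of compound 1 apart from both 3-substituted compounds. No supporting evidence explains these results. Going by these compounds, whether an amine or a carboxylic acid on this aromatic carbon would shift the number remains open.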